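Extending the Chain From Compound 1 to Compound 3

The source may report more compounds than this note shows. Statements on the series, on what has been measured and on what is new or still open speak of the compounds shown alone.

Measured so far:
compound 1 `O=C(NCCCCc1ccccc1)n1c(=O)oc2ccccc21` — 64 nM
compound 2 `O=C(NCCCCc1ccccc1)n1c(=O)oc2cc([N+](=O)[O-])ccc21` — 3 nM

In an assay on HEK293 cells for inhibition of acid ceramidase (Homo sapiens), with a stated time of 10 min (a higher number here means a weaker inhibitor, a lower number a stronger inhibitor), compound 1 gives 64 nM, the highest of the two numbers; its nearest neighbour is compound 2, reached through a 21-fold lower number from compound 1 to compound 2 (1.33 log units; beyond the scatter). Compound 3 `O=C(NCCCCCCc1ccccc1)n1c(=O)oc2ccccc21` is not yet measured. It differs from compound 1 by phenethyl in place of phenyl on a saturated chain carbon, four bonds along the chain from an amide-type nitrogen, so the chain between the shared core and the terminal ring grows while everything else stays as in compound 1.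

For the measured compounds named here, the only measured step, from compound 1 to compound 2, alters a substituent on the aromatic part of the shared core and leaves the chain untouched. Going by the values given here, it therefore does not bear on the change from compound 1 to compound 3, and there is no measured pair that does. With nothing to point in either direction, the expected step in this assay is none beyond the scatter, with wider uncertainty than a measured step would carry. Compound 3 is therefore estimated to give about 60 nM in this assay, within 15 nM to 250 nM, which would mean a 1.1-fold lower number from compound 1 to compound 3 (0.03 log units; within the scatter).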

Compound 3, half-maximal inhibitory concentration: 51 nM
Compound 3: middle estimate off by 1.2-fold (0.07 log units), on the high side; measured number inside the range.
By their numbers in this assay, from the lowest: compound 2; then compounds 3 and 1 (each within the scatter of the next).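

In this assay the chain position proves tolerant of this one extension: phenethyl in place of phenyl on a saturated chain carbon, four bonds along the chain from an amide-type nitrogen, gives a 1.3-fold lower number from compound 1 to compound 3 (0.10 log units; within the scatter). The earlier compounds shown here showed only that the aromatic part of the shared core can respond strongly, through a 21-fold lower number from compound 1 to compound 2 (1.33 log units; beyond the scatter), and said nothing about the chain, whereas this pair shows that the added length leaves the reading indistinguishable from that of compound 1, with the terminal ring and the rest of the molecule held constant. No separate measurement bears on what lies behind this result.

The compounds shown leave open whether a shorter or longer chain would also read the same, or whether this tolerance is limited to the one extension seen here, and whether an amine or a carboxylic acid on the chain would be accepted. They also leave open whether nitro on the aromatic part of the shared core and the phenethyl extension would combine, since no compound shown carries both.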